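The source may hold more compounds than are shown below. What is called first, only, known or untested is meant among the compounds shown, and "the series" means these compounds.

In an ADME assay on Vero cells (Chlorocebus sabaeus) for cytotoxicity, read by neutral red uptake, tested at 787 ug/mL (on this read-out lower numbers stand for a stronger effect and higher numbers for a weaker effect at the one concentration tested), compound 2 `O=C1CSC(c2ccc([N+](=O)[O-])cc2)N1CCN1CCCCC1` gives 21% and stands lowest of the two numbers shown; its nearest neighbour is compound 1 `COc1ccc(C2SCC(=O)N2CCN2CCCCC2)cc1`, which gives 33%. Within the data shown here, only one measured step bears on the question: a number 12 percentage points lower from compound 1 to compound 2 (beyond the scatter). Compound 3 `O=C1CSC(c2ccc(F)cc2)N1CCN1CCCCC1` differs from compound 2 by fluoro in place of nitro on an aromatic carbon. Among the measured compounds shown here, removing the nitro undoes part of that earlier change, while no measured step shows fluoro itself, so a modest step back upward is expected, a number 9 percentage points higher from compound 2 to compound 3 (within the scatter). Compound 3 is therefore estimated at 30%, within a range from 15% to 50%.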

Compound 3, a percentage reported as activity, at one concentration (the size of the read-out at that concentration, not a potency): 17%
Estimate against measurement, compound 3: 13 percentage points above; measured number inside the range.
By their numbers in this assay, from the lowest: compounds 3 and 2 (each within the scatter of the next); then compound 1.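

In this assay fluoro in place of nitro gives a number 4 percentage points lower from compound 2 to compound 3 (within the scatter), so at this place on the ring, para to a large group, these two groups cannot be told apart. Among these compounds, the lower number is thus not unique to nitro: fluoro in place of methoxy gives a number 16 percentage points lower from compound 1 to compound 3 (beyond the scatter), which leaves methoxy as the one group of the three that stands apart. Nothing shown here explains this difference.

Still open, on these data alone, is how an amine or a carboxylic acid at this place would read. Whether a longer chain in place of methoxy would also give a higher number is open too.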